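A Single Stereocentre Flipped on a Sugar-Linked Selenium Heterocycle

The source may report more compounds than this note shows. Statements on the series, on what has been measured and on what is new or still open speak of the compounds shown alone.

Compound 2 `CC(=O)OC[C@H]1O[C@@H](n2[se]c3ccccc3c2=O)[C@H](OC(C)=O)[C@@H](OC(C)=O)[C@@H]1OC(C)=O` has the highest number among the two measured in a functional assay on A549 cells (Homo sapiens) for cytotoxicity, read by resazurin assay, with a stated time of 48 h (a higher number here means a weaker inhibitor, a lower number a stronger inhibitor), giving 20400 nM. Among the measured compounds shown here, its only neighbour, compound 1 `CC(=O)O[C@@H]1[C@@H](OC(C)=O)[C@H](OC(C)=O)CO[C@H]1n1[se]c2ccccc2c1=O`, gives 7000 nM in this assay, and the step of a 2.9-fold higher number from compound 1 to compound 2 (0.46 log units; beyond the scatter) came from adding a group. Compound 3 `CC(=O)OC[C@H]1O[C@@H](n2[se]c3ccccc3c2=O)[C@H](OC(C)=O)[C@@H](OC(C)=O)[C@H]1OC(C)=O` is different in kind: the two compounds have the same atoms and bonds and differ only in configuration as drawn: 1 of 5 stereo elements differ; a stereocentre at a saturated ring carbon is drawn R in compound 2 and S in compound 3. For the measured compounds named here, no measured step involves such a change of configuration alone, so the one known step offers no guide, and the expected step of a 1.0-fold lower number from compound 2 to compound 3 (0.01 log units; within the scatter) is within the usual scatter. Compound 3 is therefore estimated at 20000 nM, with a range from 8000 nM to 50000 nM.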

Compound 3, half-maximal inhibitory concentration: 25200 nM
For compound 3 the middle estimate is 1.3-fold (0.10 log units) below the measured one; low and high end bracket the measured number.
By their numbers in this assay, from the lowest: compound 1; then compounds 2 and 3 (each within the scatter of the next).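

In this assay, turning this saturated ring carbon from R to S gives a 1.2-fold higher number from compound 2 to compound 3 (0.09 log units; within the scatter), so at this stereocentre the change of configuration has no effect that can be told from the scatter. The earlier step added a group, whereas this comparison tests spatial arrangement alone: the fact that compounds 2 and 3 differ only in the configuration as drawn. From the compounds shown here alone, whether the other stereocentres are equally tolerant stays open. So does what happens in this assay when the group on this ring carbon gives way to an amine or a carboxylic acid.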